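This account rests on a few compounds, and the source may have more. Where it says the series, first, only, none or still open, it means among the compounds named here.

Compound 1 `Brc1cn2ccnc2c(-c2ccc3ncn(C4CCCCC4)c3c2)n1` carries bromo on the shared core and gives 19.8% in a functional assay on UACC-62 cells (Homo sapiens) for inhibition, read by sulforhodamine B assay, with a stated time of 48 h, tested at 10 uM; on this read-out higher numbers stand for more inhibition at the one concentration tested (going by the name of the read-out) and lower numbers for less inhibition. Compound 2 `O=Cc1ccc(-c2cn3ccnc3c(-c3ccc4ncn(C5CCCCC5)c4c3)n2)cc1` replaces that bromo with 4-formylphenyl and gives 37.1%, a change of a number 17.3 percentage points higher from compound 1 to compound 2 (beyond the scatter). Compound 3 `CC(=O)c1ccc(-c2cn3ccnc3c(-c3ccc4ncn(C5CCCCC5)c4c3)n2)cc1` bears 4-acetylphenyl instead and gives 18.5%. Among these three, compound 3 has the lowest number: from compound 1 it differs by a number 1.3 percentage points lower from compound 1 to compound 3 (within the scatter), which is within the scatter, while from compound 2 it differs by a number 18.6 percentage points lower from compound 2 to compound 3 (beyond the scatter), which is beyond it.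

Compound 4 `Brc1ccc(-c2cn3ccnc3c(-c3ccc4ncn(C5CCCCC5)c4c3)n2)cc1` is the next step from compound 3: bromo in place of acetyl on an aromatic carbon. Going by the values given here, no measured step replaces acetyl with bromo on that phenyl ring, so the guidance is indirect. The step from compound 2 to compound 3 shows that altering the group on the carbonyl carbon moved the read-out by a number 18.6 percentage points lower from compound 2 to compound 3 (beyond the scatter), and the step from compound 1 to compound 3 shows that 4-acetylphenyl in place of bromo on the core changed it by only a number 1.3 percentage points lower from compound 1 to compound 3 (within the scatter). The three numbers span a narrow range, and compound 4 is expected to stay within it, so a step of a number 3.5 percentage points higher from compound 3 to compound 4 (within the scatter), not beyond the scatter, is estimated. Compound 4 is therefore expected to give about 22%, between 8% and 38%.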

Compound 4, a percentage reported as inhibition, at one concentration (the size of the read-out at that concentration, not a potency): 46.9%
Compound 4: the middle estimate sits 24.9 percentage points below what was measured; measured number above the stated range.
By their numbers in this assay, from the lowest: compounds 3 and 1 (each within the scatter of the next); then compounds 2 and 4 (each within the scatter of the next).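

Exchanging acetyl for bromo on the aromatic carbon para to a large group gave a number 28.4 percentage points higher from compound 3 to compound 4 (beyond the scatter) in this assay, so this position on the phenyl ring responds to the group it carries, even though the change removes only a small acetyl for a single bromine atom. Formyl and bromo at this position cannot be told apart, at a number 9.8 percentage points higher from compound 2 to compound 4 (within the scatter), which leaves compound 3 with its acetyl as the one low member of the three phenyl-bearing compounds. The earlier compounds shown here suggested that swapping the bromo on the core for a substituted phenyl ring could leave the read-out unchanged, but a number 27.1 percentage points higher from compound 1 to compound 4 (beyond the scatter) shows that the outcome of that swap depends on the group on the phenyl ring.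

No available evidence accounts for the difference between these groups. Going by these compounds, it remains open whether an amine, a carboxylic acid or a methoxy group at this position would read like bromo and formyl or like acetyl, and whether these differences would persist at other concentrations.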